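Swapping a Furan for a Thiophene in an Adrenergic Agonist Series

The source may hold more compounds than are shown below. What is called first, only, known or untested is meant among the compounds shown, and "the series" means these compounds.

Compound 1, `c1ccc(-c2cnccn2)c(OCC2=NCCN2)c1`: 2.51 nM in a functional assay for activation of Alpha-1A adrenergic receptor (Homo sapiens), read by calcium flux; a lower number here means that less compound is needed, a higher number that more compound is needed for the effect
Compound 2, `Cc1ccoc1-c1ccccc1OCC1=NCCN1`: 3.16 nM in this assay

Among the compounds with values here, compound 2 holds the higher of the two numbers measured so far, but its only neighbour is compound 1, and the step of a 1.3-fold higher number from compound 1 to compound 2 (0.10 log units; within the scatter) sits within the usual scatter, so the two compounds are not told apart by this assay. That single step is the only one available to judge the next change.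

Compound 3, `Cc1ccc(-c2ccccc2OCC2=NCCN2)s1`, differs from compound 2 in one place: 5-methylthiophen-2-yl in place of 3-methylfuran-2-yl on an aromatic carbon. Within the data shown here, the one measured step at this position exchanged a six-membered ring for a five-membered one without a change beyond the scatter; the present change keeps a five-membered ring with a single hetero atom and moves only the methyl and the kind of hetero atom. No change beyond the scatter is therefore expected in this assay, and the expected step is a 1.1-fold higher number from compound 2 to compound 3 (0.04 log units; within the scatter). Compound 3 is estimated to give about 3.5 nM, with a likely range from 1.5 nM to 8 nM.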

Compound 3, half-maximal effective concentration: 25.1 nM
Estimate against measurement, compound 3: 7.2-fold (0.86 log units) below, and the stated range ends below it.
By their numbers in this assay, from the lowest: compounds 1 and 2 (each within the scatter of the next); then compound 3.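

This position is not indifferent to which five-membered ring it carries. In this assay the exchange of 3-methylfuran-2-yl for 5-methylthiophen-2-yl gives a 7.9-fold higher number from compound 2 to compound 3 (0.90 log units; beyond the scatter) even though both groups have the same heavy-atom, donor and acceptor counts, and replacing pyrazin-2-yl with the same thiophene gives a 10-fold higher number from compound 1 to compound 3 (1.00 log units; beyond the scatter), so the earlier step within the scatter did not mean that every aromatic ring fits equally well here. Nothing measured in this set accounts for the change.

The hetero atom and the place of the methyl changed together, and the compounds shown cannot separate the two. A comparison of 3-methylthiophen-2-yl or 5-methylfuran-2-yl with compound 2 and compound 3 would show which of the two changes goes with the higher number.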